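This account rests on a few compounds, and the source may have more. Where it says the series, first, only, none or still open, it means among the compounds named here.

Measured compounds in a functional assay on MCF7 cells (Homo sapiens) for antiproliferative activity; a lower number here means a stronger inhibitor, a higher number a weaker inhibitor:
compound 1 `COc1cccc(Oc2ccc3cc(NC(=O)c4ccc(OC(C)=O)c(CC=C(C)C)c4)c(=O)oc3c2C)c1` — 15700 nM
compound 2 `COc1cccc(Oc2ccc3cc(NC(=O)c4ccc(O)c(CC=C(C)C)c4)c(=O)oc3c2C)c1` — 62800 nM
compound 3 `COc1cccc(Oc2ccc3cc(NC(=O)c4ccc(OC)c(-c5cccc(OC)c5)c4)c(=O)oc3c2C)c1` — > 100000 nM

Compound 2 holds the higher of the two numbers in this assay, its nearest neighbour being compound 1 at 15700 nM. Among the compounds with values here, the one single-point step measured so far runs a 4.0-fold higher number from compound 1 to compound 2 (0.60 log units; beyond the scatter), a change on the phenol oxygen of the benzamide part of the shared core. Compound 3 returns only a limit in this assay, > 100000 nM; the shared core is thus able to lose its measurable activity entirely, as the limit of > 100000 nM in this assay, at which 1 of the 3 values shown sits, shows.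

Compound 4 `COc1ccc(Cc2ccc3cc(NC(=O)c4ccc(O)c(CC=C(C)C)c4)c(=O)oc3c2C)cc1` is not yet measured. It differs from compound 2 by 4-methoxybenzyl in place of 3-methoxyphenoxy on an aromatic carbon. Within the data shown here, no measured step concerns this position; the step from compound 1 to compound 2 sits elsewhere on the core and offers no guide to its size or direction. The expectation for compound 4 is therefore anchored on compound 2 alone, with a wide band: compound 4 is estimated at 55000 nM, between 12000 nM and 250000 nM. This estimate means a step of a 1.1-fold lower number from compound 2 to compound 4 (0.06 log units; within the scatter), expected to stay within the scatter, with a real chance that compound 4, like compound 3, gives only a limit.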

Compound 4, half-maximal inhibitory concentration: 13300 nM
For compound 4 the middle estimate is 4.1-fold (0.62 log units) above the measured one; the range from low to high includes it.
By their numbers in this assay, from the lowest: compounds 4 and 1 (each within the scatter of the next); then compound 2. At a limit, above all of these: compound 3.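

In this assay, within the data shown here, this position on the aromatic carbon ortho to a methyl group proves responsive: the exchange of 3-methoxyphenoxy for 4-methoxybenzyl gives a 4.7-fold lower number from compound 2 to compound 4 (0.67 log units; beyond the scatter), a modest step beyond the scatter and the first measured change at this place. The direction is toward stronger inhibition, so with the phenol of compound 2 kept, the 3-methoxyphenoxy group is not required at this position for the activity seen, and a carbon-linked aryl group serves here at least as well. The change alters both the atom joining the aromatic ring to the core and the place of the methoxy group on that ring, and nothing in the data shown accounts for the step or assigns it to either alteration.

A 3-methoxybenzyl or a 4-methoxyphenoxy group at this position would separate those two alterations, while an unsubstituted benzyl group would show what the methoxy group contributes at all. Also open, going by these compounds, is whether the step from a change at this position carries over to the acetylated phenol of compound 1, and how an aminomethyl or a carboxylic acid group on the aromatic ring would fare here.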